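Compound 3 to compound 4: a phenyl swap

The source may report more compounds than this note shows. Statements on the series, on what has been measured and on what is new or still open speak of the compounds shown alone.

In a physicochemical assay for solubility, read by HPLC, in phosphate buffer, measured as kinetic solubility, at pH 7.4 (on this read-out higher numbers stand for higher solubility and lower numbers for lower solubility), compound 3 `Cc1ccc(-c2cc(C(=O)O)c(C)n2-c2ccc(S(N)(=O)=O)cc2)cc1` gives 10000 nM. Compound 1 `CCOC(=O)c1cc(-c2cccc(Cl)c2)n(-c2ccc(S(N)(=O)=O)cc2)c1C` gives 9200 nM, within the scatter of compound 3. Compound 2 `Cc1c(C(=O)O)cc(-c2ccc(F)cc2)n1-c1ccc(S(N)(=O)=O)cc1` stands apart from both at 50000 nM.

The next compound is compound 4 `Cc1c(C(=O)O)cc(-c2cccc(Cl)c2)n1-c1ccc(S(N)(=O)=O)cc1`, which has 3-chlorophenyl in place of 4-methylphenyl on an aromatic carbon. The carboxy group and the methyl group on the five-membered aromatic ring stay as they are.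

For the measured compounds named here, only one measured step touches this substituent: a 5.0-fold lower number from compound 2 to compound 3 (0.70 log units; beyond the scatter). It is modest but beyond the scatter, so a change of group at this place can register in this assay. It involves neither the entering nor the leaving group's chlorine or position, however, and it gives no direction for the present swap. Going by the values given here, compound 1 carries the same 3-chlorophenyl and gives 9200 nM, but it has an ester where compound 4 has the carboxy group, so no measured pair isolates the swap.

With compound 3 at 10000 nM as the anchor, no shift beyond the scatter is expected, and the estimated step is a 1.2-fold higher number from compound 3 to compound 4 (0.08 log units; within the scatter). The expected value for compound 4 is 12000 nM, with an estimated range from 4000 nM to 40000 nM.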

Compound 4, solubility: 100000 nM
Estimate against measurement, compound 4: 8.3-fold (0.92 log units) below; the whole stated range lies below it.
By their numbers in this assay, from the lowest: compounds 1 and 3 (each within the scatter of the next); then compounds 2 and 4 (each within the scatter of the next).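

With the carboxy group held fixed, the swap to 3-chlorophenyl on this aromatic carbon registers beyond the scatter in this assay (a 10-fold higher number from compound 3 to compound 4 (1.00 log units; beyond the scatter)), so the step already seen at this place is joined by a second one that also ends at compound 3 as the low partner. For the compounds shown here, the step to 3-chlorophenyl from 4-fluorophenyl stays within the scatter (a 2.0-fold higher number from compound 2 to compound 4 (0.30 log units; within the scatter)), which leaves 4-methylphenyl in compound 3 as the one group that stands apart among the three carboxy compounds, while 4-fluorophenyl and 3-chlorophenyl cannot be told apart. The series also gains its first pair that isolates the ethyl ester from the carboxy group with 3-chlorophenyl held constant, and this change too lies beyond the scatter (an 11-fold higher number from compound 1 to compound 4 (1.04 log units; beyond the scatter)).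

Nothing measured on these compounds accounts for any of these steps. Three groups at this place and one ester pair cannot show whether the separation of 4-methylphenyl belongs to the methyl group itself, and an unsubstituted phenyl here or a primary amide in place of the carboxy group would test how far each of these two steps carries.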